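Swapping the ring on compound 3 for pyrrolidine

This account rests on a few compounds, and the source may have more. Where it says the series, first, only, none or still open, it means among the compounds named here.

compound 1 `CC(C(=O)Nc1cc(C2CC2)[nH]n1)c1ccc(N2C(=O)CCC2C)cc1`: 6400 nM
compound 2 `C[C@H](C(=O)Nc1cc(C2CC2)[nH]n1)c1ccc(N2CCCC2)cc1`: 220 nM
compound 3 `CC(C(=O)Nc1cc(C2CC2)[nH]n1)c1ccc(N2CCNC2=O)cc1`: 2250 nM

In a functional assay on A2780 cells (Homo sapiens) for inhibition (a lower number here means a stronger inhibitor, a higher number a weaker inhibitor), compound 3 holds the middle place of the three, with compound 1 higher and compound 2 lower. Compound 4 `CC(C(=O)Nc1cc(C2CC2)[nH]n1)c1ccc(N2CCCC2)cc1` differs from it in one place: pyrrolidin-1-yl in place of 2-oxoimidazolidin-1-yl on an aromatic carbon. The pyrrolidin-1-yl group replaces the 2-oxoimidazolidin-1-yl group on an aromatic carbon. Among the compounds with values here, the one measured ring swap at this carbon was a 2.8-fold lower number from compound 1 to compound 3 (0.45 log units; beyond the scatter), which is modest. A closer guide is compound 2 at 220 nM, which has the same atoms as compound 4 but is drawn as a single mirror-image form. A clearly lower number is therefore expected in this assay, an expected 6.4-fold lower number from compound 3 to compound 4 (0.81 log units; beyond the scatter). For compound 4 the estimated value is 350 nM, with an expected range of 150 nM to 750 nM.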

Compound 4, half-maximal inhibitory concentration: 370 nM
Beside the measured number, compound 4's estimate is 1.1-fold (0.02 log units) below it, and the stated range covers the measured number.
By their numbers in this assay, from the lowest: compounds 2 and 4 (each within the scatter of the next); then compound 3; then compound 1.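

In this assay, the plain pyrrolidin-1-yl ring on this aromatic carbon outperforms both rings carrying a carbonyl, with a 6.1-fold lower number from compound 3 to compound 4 (0.78 log units; beyond the scatter) and a 17-fold lower number from compound 1 to compound 4 (1.24 log units; beyond the scatter). The step of a 1.7-fold higher number from compound 2 to compound 4 (0.23 log units; within the scatter) shows that the two pyrrolidin-1-yl compounds read alike, and only one thing separates them: the fact that one of compounds 2 and 4 is drawn with a defined configuration and the other without, at the place where they differ

The compounds shown leave open whether the carbonyl itself accounts for these steps, since the rings differ in other atoms too. They also leave open how a morpholine ring or an open-chain dimethylamino group would read at this carbon, and how the opposite mirror-image form of compound 2 would read.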